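Halogen swap on the benzoyl arm of compound 3

This account rests on a few compounds, and the source may have more. Where it says the series, first, only, none or still open, it means among the compounds named here.

Compound 1 `COc1cc(N(Cc2nc3ccccc3[nH]2)S(=O)(=O)c2ccc(F)cc2)cc(OC)c1OC`: 5680 nM
Compound 2 `COc1cc(N(Cc2nc3ccccc3[nH]2)S(=O)(=O)c2ccccc2Cl)cc(OC)c1OC`: 19100 nM
Compound 3 `COc1cc(N(Cc2nc3ccccc3[nH]2)C(=O)c2ccc(F)cc2)cc(OC)c1OC`: 23600 nM

Of the compounds shown here, three sharing one core have been measured in a functional assay on MGC-803 cells (Homo sapiens) for inhibition, read by MTT assay, with a stated time of 48 h; a lower number here means a stronger inhibitor, a higher number a weaker inhibitor. Compound 3 gives the highest number of the three; its gap to compound 2 lies within the scatter, while the step of a 4.2-fold higher number from compound 1 to compound 3 (0.62 log units; beyond the scatter) lies beyond it. Compound 4 `COc1cc(N(Cc2nc3ccccc3[nH]2)C(=O)c2ccc(Br)cc2)cc(OC)c1OC` is the next compound; the change from compound 3 is bromo in place of fluoro on an aromatic carbon, that is, (4-fluorophenyl)carbonyl to (4-bromophenyl)carbonyl.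

For the measured compounds named here, none of the measured steps concerns a halogen exchange on this ring. The step of a 3.4-fold higher number from compound 1 to compound 2 (0.53 log units; beyond the scatter) moves a halogen between sulfonyl-bound phenyl rings, and the step of a 1.2-fold higher number from compound 2 to compound 3 (0.09 log units; within the scatter) stays within the scatter; neither speaks to bromo against fluoro at the same position. Going by the values given here, with no direct precedent, the expectation for compound 4 is a step of a 1.2-fold lower number from compound 3 to compound 4 (0.07 log units; within the scatter), not beyond the scatter. Compound 4 is therefore estimated at 20000 nM, with a range of 8000 nM to 50000 nM.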

Compound 4, half-maximal inhibitory concentration: 14600 nM
The estimate for compound 4 lay 1.4-fold (0.14 log units) above the measured number, within the range that was stated.
By their numbers in this assay, from the lowest: compound 1; then compounds 4, 2 and 3 (each within the scatter of the next).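

In this assay, exchanging the halogen on the benzoyl arm leaves the number within the scatter (a 1.6-fold lower number from compound 3 to compound 4 (0.21 log units; within the scatter)), so fluoro and bromo at this place, para to a large group, cannot be told apart here. Compound 4 also cannot be separated from the sulfonyl compound 2 (a 1.3-fold lower number from compound 2 to compound 4 (0.12 log units; within the scatter)), while the gap to compound 1 stays beyond the scatter (a 2.6-fold higher number from compound 1 to compound 4 (0.41 log units; beyond the scatter)), so the bromo group does not bring the benzoyl arm level with the (4-fluorophenyl)sulfonyl arm. No measurement at hand offers an explanation for these numbers.

Going by these compounds, whether a methoxy group or an amine at the same place would move the number beyond the scatter remains open. So does whether bromo in place of fluoro on the sulfonyl-bound ring of compound 1 would behave as it does on the benzoyl arm.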